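The compounds below may be only part of what the source reports. "The series", "measured", "known", "first", "only" and "open" are said of these compounds alone.

Measured in a functional assay on KB 3-1 cells (Homo sapiens) for cytotoxicity, read by MTT assay, with a stated time of 72 h; a lower number here means a stronger inhibitor, a higher number a weaker inhibitor:
compound 1 `O=C1Nc2ccccc2/C1=N/NC(=S)Nc1ccccc1` gives 3530 nM
compound 2 `C=CCNC(=S)N/N=C1\C(=O)Nc2ccccc21` gives 26100 nM
compound 3 `O=C1Nc2ccccc2/C1=N/NC(=S)Nc1cccc(Cl)c1` gives 1870 nM

Compound 1 stands second highest of the three numbers. Its nearest neighbour is compound 3, reached by a 1.9-fold lower number from compound 1 to compound 3 (0.28 log units; within the scatter), a step within the scatter; its furthest is compound 2, reached by a 7.4-fold higher number from compound 1 to compound 2 (0.87 log units; beyond the scatter), a step beyond the scatter. The replacement of allyl by 3-chlorophenyl gives a 14-fold lower number from compound 2 to compound 3 (1.14 log units; beyond the scatter), so the aryl group on the thiourea nitrogen matters far more in this assay than the substituent on that aryl ring.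

Compound 4 `O=C1Nc2ccccc2/C1=N/NC(=S)Nc1ccc(F)cc1` differs from compound 1 in one place: fluoro in place of hydrogen on an aromatic carbon. Within the data shown here, the only measured step that bears on it is the chloro-for-hydrogen change on the same aryl ring, which stayed within the scatter. Nothing here separates fluoro from chloro at this position, so no step beyond the scatter is expected in this assay; the estimated change is a 1.2-fold lower number from compound 1 to compound 4 (0.07 log units; within the scatter). For compound 4 the expected value is 3000 nM, in a range from 1200 nM to 7500 nM.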

Compound 4, half-maximal inhibitory concentration: 14200 nM
For compound 4 the middle estimate is 4.7-fold (0.68 log units) below the measured one; measured number outside the range, above it.
By their numbers in this assay, from the lowest: compounds 3 and 1 (each within the scatter of the next); then compounds 4 and 2 (each within the scatter of the next).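

In this assay the aryl ring on the thiourea does not accept every small substituent: fluoro in place of hydrogen, para to a large group, gives a 4.0-fold higher number from compound 1 to compound 4 (0.60 log units; beyond the scatter) and so goes beyond the scatter, which the chloro change in compound 3 did not. The two halogenated aryl groups are not interchangeable either, with a 7.6-fold higher number from compound 3 to compound 4 (0.88 log units; beyond the scatter) for a change that alters both the halogen and its place on the ring. An aryl group alone does not secure the gain over allyl, since a 1.8-fold lower number from compound 2 to compound 4 (0.26 log units; within the scatter) stays within the scatter, and compound 4 goes against the earlier reading.

No data at hand account for this shift. As far as these compounds go, whether it follows the fluoro group or the ring place stays open, and 4-chlorophenyl and 3-fluorophenyl groups would separate the two, while a methoxy group or an amine at the same place would show how far the shift extends beyond halogens.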